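The compounds below may be only part of what the source reports. "The series", "measured", "known", "first", "only" and "open" are said of these compounds alone.

Compound 2 (`COc1cc(-c2nc3cc(/C=C4\SC(=O)N(CC(=O)N5CCCCC5)C4=O)ccc3[nH]2)cc(OC)c1OC`) was tested in an ADME assay on HEK-293T cells (Homo sapiens) for inhibition, read by MTT assay, with a stated time of 48 h (on this read-out lower numbers stand for stronger inhibition and higher numbers for weaker inhibition), and gave 21500 nM. Compound 1 (`COc1cc(-c2nc3cc(/C=C4\SC(=O)N(CC(=O)N5CCOCC5)C4=O)ccc3[nH]2)cc(OC)c1OC`) gave 18800 nM in this assay, so the two numbers lie within the scatter of each other, as the step of a 1.1-fold higher number from compound 1 to compound 2 (0.06 log units; within the scatter) shows. Compound 3 (`COc1cc(-c2nc3cc(/C=C4\SC(=O)N(Cc5ccccc5)C4=O)ccc3[nH]2)cc(OC)c1OC`) differs from compound 2 by phenyl in place of (piperidin-1-yl)carbonyl on a saturated chain carbon bound to an amide-type nitrogen in a ring. Among the measured compounds shown here, only that one step bears on the change, and it was flat, while no measured pair shows the amide being removed. Compound 3 is therefore expected to give 20000 nM, within 7000 nM to 60000 nM, a step of a 1.1-fold lower number from compound 2 to compound 3 (0.03 log units; within the scatter) that is estimated to stay within the scatter.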

Compound 3, half-maximal inhibitory concentration: 8210 nM
Estimate against measurement, compound 3: 2.4-fold (0.39 log units) above; the measured number falls inside the stated range.
By their numbers in this assay, from the lowest: compound 3; then compounds 1 and 2 (each within the scatter of the next).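

This position does respond to the group it carries, which the flat step between the two amides could not show. In this assay the change to phenyl gives a 2.6-fold lower number from compound 2 to compound 3 (0.42 log units; beyond the scatter) and also a 2.3-fold lower number from compound 1 to compound 3 (0.36 log units; beyond the scatter) from the other amide, so both steps are modest and point the same way.

The compounds shown leave open whether losing the carbonyl or gaining the phenyl ring carries this step, as the two change together. A pyridyl ring, a simple ethyl chain or a carboxylic acid at this place would help separate them. No measurement given here accounts for the step.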